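Methyl for chloro on the fused carbocycle of compound 2

The compounds below may be only part of what the source reports. "The series", "measured", "known", "first", "only" and "open" are said of these compounds alone.

Measured so far:
compound 1 `Cc1cc(Nc2nc(NCc3cc(F)ccc3F)nc3ccccc23)n[nH]1`, 6 nM
compound 2 `Cc1cc(Nc2nc(NCc3ccc(F)cc3F)nc3cc(Cl)ccc23)n[nH]1`, 24 nM

In an assay for inhibition of BDNF/NT-3 growth factors receptor (Homo sapiens), read by HTRF, with a stated time of 40 min, in the presence of a further agent that is not named here (a lower number here means a stronger inhibitor, a higher number a weaker inhibitor), compound 1 gives 6 nM. For the measured compounds named here, compound 2 gives 24 nM, the higher of the two numbers, and its gap to compound 1 lies beyond the scatter; the two differ in more than one place, so no single step is assigned. Compound 3 `Cc1ccc2c(Nc3cc(C)[nH]n3)nc(NCc3ccc(F)cc3F)nc2c1` differs from compound 2 by methyl in place of chloro on an aromatic carbon. With no measured step of this kind in the series, the expected step is small, with no clear direction, and likely within the scatter. The expected step is a 1.2-fold lower number from compound 2 to compound 3 (0.08 log units; within the scatter). Compound 3 is expected near 20 nM, between 8 nM and 50 nM.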

Compound 3, half-maximal inhibitory concentration: 9 nM
For compound 3 the middle estimate is 2.2-fold (0.35 log units) above the measured one; measured number inside the range.
By their numbers in this assay, from the lowest: compounds 1 and 3 (each within the scatter of the next); then compound 2.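

In this assay methyl in place of chloro gives a 2.7-fold lower number from compound 2 to compound 3 (0.43 log units; beyond the scatter) and so shows that this carbon of the six-membered aromatic ring responds to the exchange, though modestly. For the compounds shown here, this is the first single-place step, and it involves one heavy atom for one, with no hydrogen-bond donors or acceptors on either side. No measurement shown bears on the cause of this step. Open, on these data alone, are how methoxy, an amine or a nitrile would read at this carbon, and whether the step holds with the fluorines placed as in compound 1.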